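Swapping the Benzyl for a Benzothiophenyl: Cytotoxicity Outlook

The compounds below may be only part of what the source reports. "The series", "measured", "known", "first", "only" and "open" are said of these compounds alone.

Compound 1 `CCC(CC)O[C@@H]1C=C(C(=O)O)C[C@H](NCc2ccc(Cc3ccccc3)cc2)[C@H]1NC(C)=O`: in an ADME assay on cells (Fibroblast, Gallus gallus) for cytotoxicity, read by CCK-8 assay, with a stated time of 48 h (a higher number here means that more compound is tolerated, a lower number that less compound is tolerated), compound 1 gives > 200000 nM, which is a limit of the assay.
Compound 2 `CCC(CC)O[C@@H]1C=C(C(=O)O)C[C@H](NCc2ccc(SC(C)CC)cc2)[C@H]1NC(C)=O`: in this assay compound 2 gives > 200000 nM, also a limit.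
Compound 3 `CCC(CC)O[C@@H]1C=C(C(=O)O)C[C@H](NCc2ccc(SC3CCCCC3)cc2)[C@H]1NC(C)=O`: in this assay compound 3 gives > 200000 nM, also a limit.

Compound 1 therefore stands only at a limit, and the same holds for the two other values, since all three sit at the limit of > 200000 nM in this assay, at which 3 of the 3 values shown sit. Compound 4 `CCC(CC)O[C@@H]1C=C(C(=O)O)C[C@H](NCc2ccc(-c3ccc4sccc4c3)cc2)[C@H]1NC(C)=O` differs from compound 1 in one place: 1-benzothiophen-5-yl in place of benzyl on an aromatic carbon. Two measured steps replace the same benzyl on that aromatic carbon, a step that the two limits leave unreadable from compound 1 to compound 2 and a step that the two limits leave unreadable from compound 1 to compound 3; the remaining step, a step that the two limits leave unreadable from compound 2 to compound 3, is just as unreadable. No size and no direction can be drawn from any of them. Nothing among these compounds points to a step beyond the scatter, so the expectation for compound 4 is that this assay will again report a limit rather than a number, meaning a step that the limit leaves unreadable from compound 1 to compound 4. Compound 4 is thus estimated at 300000 nM, between 150000 nM and 1000000 nM.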

Compound 4, half-maximal cytotoxic concentration: > 200000 nM
Compound 4: a limit, no number (the forecaster's own chance of this, stated with the estimate: 80%); the middle value is on the limit's open side.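

Among the compounds shown here, compound 4 also gives only a limit, so no step to it from compound 1, compound 2 or compound 3 can be read: the limit of > 200000 nM in this assay, at which 4 of the 4 values shown sit. The compounds shown leave open how much of each one the cells tolerate, and whether these group swaps change that tolerance at all.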